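Chloro to hydroxy on the pyridine amide of compound 2

The source may hold more compounds than are shown below. What is called first, only, known or untested is meant among the compounds shown, and "the series" means these compounds.

Measured so far:
compound 1 `COc1cc(F)c(NC(=O)c2ccncc2)cc1Nc1nccc(-c2cn(C)c3ccccc23)n1` — 4370 nM
compound 2 `COc1cc(F)c(NC(=O)c2ccnc(Cl)c2)cc1Nc1nccc(-c2cn(C)c3ccccc23)n1` — 4330 nM

In a functional assay on NCI-H1975 cells (Homo sapiens) for antiproliferative activity, read by MTT assay, with a stated time of 72 h (on this read-out lower numbers stand for stronger inhibition and higher numbers for weaker inhibition), compound 1 gives 4370 nM and compound 2 gives 4330 nM. Among the measured compounds shown here, the two numbers sit level, as the one measured step shows: a 1.0-fold lower number from compound 1 to compound 2 (0.00 log units; within the scatter). Compound 2 therefore stands on a par with compound 1 in this assay, with nothing between them beyond the scatter.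

Compound 3 `COc1cc(F)c(NC(=O)c2ccnc(O)c2)cc1Nc1nccc(-c2cn(C)c3ccccc23)n1` is the next member. The change from compound 2 is hydroxy in place of chloro on an aromatic carbon, at the same aromatic carbon where the chloro of compound 2 was introduced. For the measured compounds named here, only the step from compound 1 to compound 2 bears on this position, and it was flat; a second swap there, chloro for hydroxy, is expected to stay near the same figure, with no step beyond the scatter, that is a 1.0-fold higher number from compound 2 to compound 3 (0.02 log units; within the scatter). Compound 3 is estimated at 4500 nM in this assay, within 1500 nM to 13000 nM.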

Compound 3, half-maximal inhibitory concentration: 5920 nM
Estimate against measurement, compound 3: 1.3-fold (0.12 log units) below; low and high end bracket the measured number.
By their numbers in this assay, from the lowest: compounds 2, 1 and 3 (each within the scatter of the next).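

In this assay the place next to the ring nitrogen now holds three different substituents, and hydroxy, which brings a hydrogen-bond donor and a hydrogen-bond acceptor that chloro lacks, stays within the scatter on both readings: a 1.4-fold higher number from compound 2 to compound 3 (0.14 log units; within the scatter), and a 1.4-fold higher number from compound 1 to compound 3 (0.13 log units; within the scatter). Hydrogen, chloro and hydroxy are therefore not told apart at this place, whereas the earlier compounds compared only hydrogen and chloro. No supporting evidence is available to explain this flat result.

Going by these compounds, whether an amine, a methoxy group or a carboxylic acid at the same place would also stay within the scatter remains open. So does whether a longer chain there, or a change elsewhere on the shared core, would move the number beyond the scatter.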